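Two Cores, One Chloro Removed, Growth Inhibition in Myeloma Cells

A few compounds are considered here, and "the series" means these few. Any claim that something is new, unique, unknown or untested is made for them only; others in the source may bear on it.

Measured compounds:
compound 1 `ClCc1ccc(Cn2cnc3c(Cl)ncnc32)cc1`: 9340 nM
compound 2 `ClCc1ccc(Cn2cnc3nc(Cl)nc(Cl)c32)cc1`: 28200 nM
compound 3 `ClCc1ccc(Cn2cnc3c(Cl)nc(Cl)nc32)cc1`: 3800 nM

The three measured compounds were tested in a functional assay on RPMI-8226 cells (Homo sapiens) for cytotoxicity, read by sulforhodamine B assay, with a stated time of 48 h; on this read-out higher numbers stand for weaker inhibition of growth and lower numbers for stronger inhibition of growth. Compound 3 gives 3800 nM in this assay, compound 1 gives 9340 nM, and compound 2 gives 28200 nM, the highest of the three. Compound 1 and compound 3 share a core and differ by hydrogen in place of chloro on an aromatic carbon, a change that made the step of a 2.5-fold higher number from compound 3 to compound 1 (0.39 log units; beyond the scatter). Compound 2 and compound 3 are built from the same atoms joined differently; the difference between the two cores is not broken down here.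

Compound 4 `ClCc1ccc(Cn2cnc3ncnc(Cl)c32)cc1` is not yet measured. It differs from compound 2 by hydrogen in place of chloro on an aromatic carbon, the same kind of change as from compound 3 to compound 1. Since that change on the core of compound 3 raised the number, compound 4 is expected to give a higher number than compound 2 in this assay, with the estimated step of a 2.1-fold higher number from compound 2 to compound 4 (0.33 log units; beyond the scatter) resting on a 2.5-fold higher number from compound 3 to compound 1 (0.39 log units; beyond the scatter) and on the value of compound 2, 28200 nM. The core of compound 2 is different, so the transfer is uncertain. Compound 4 is estimated at 60000 nM, between 20000 nM and 150000 nM.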

Compound 4, concentration for total growth inhibition: 2690 nM
For compound 4 the middle estimate is 22-fold (1.35 log units) above the measured one; measured number outside the range, below it.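

In this assay, putting hydrogen in place of chloro on the aromatic carbon between two ring nitrogen atoms gives a 10-fold lower number from compound 2 to compound 4 (1.02 log units; beyond the scatter), a large step that runs the opposite way to the modest step seen for the same change on the other core. Set side by side, the two steps differ in both direction and size: the same change on two cores in this assay, a 2.5-fold higher number (0.39 log units; beyond the scatter) from compound 3 to compound 1 and a 10-fold lower number (1.02 log units; beyond the scatter) from compound 2 to compound 4, 26-fold (1.41 log units) apart, beyond the scatter of two such steps. Within the data shown here, this shows that, in this series, the result of this change on one core does not carry over to the other, but with only two pairs it does not show which feature of the cores separates them or how the change would behave on any further core.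

The compounds shown leave open whether the same split between the cores appears when an amine or a methoxy group, rather than hydrogen, takes the place of the chloro. They also leave open how either core responds when a hydroxymethyl group replaces the chloromethyl group that all four compounds carry.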